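A Ring Swap Repeated on a More Potent Core

The source may report more compounds than this note shows. Statements on the series, on what has been measured and on what is new or still open speak of the compounds shown alone.

Measured compounds:
Compound 1 `CC/C(=C(/c1ccc(/C=C/C(=O)O)cc1)c1ccc2nccn2c1)c1ccccc1` gives 170 nM in a functional assay on MCF7 cells (Homo sapiens) for antiproliferative activity, read by CellTiter-Glo, with a stated time of 5 days; on this read-out higher numbers stand for weaker inhibition and lower numbers for stronger inhibition.
Compound 2 `CC/C(=C(/c1ccc(/C=C/C(=O)O)cc1)c1ccc2scnc2c1)c1ccccc1` gives 90 nM in this assay.
Compound 3 `O=C(O)/C=C/c1ccc(/C(=C(\c2ccc(F)cc2Cl)C2CCC2)c2ccc3scnc3c2)cc1` gives 3 nM in this assay.

Compound 1 and compound 2 share a core and differ in one place: a group of 9 heavy atoms (7 carbon, 2 nitrogen; one five-membered aromatic ring with 2 hetero atoms, one six-membered aromatic ring with 1 hetero atom) in place of a group of 9 heavy atoms (7 carbon, 1 nitrogen, 1 sulfur; one five-membered aromatic ring with 2 hetero atoms, one six-membered aromatic ring of carbon only), on a double-bonded chain carbon bound to an aromatic carbon and a double-bonded chain carbon. The step of a 1.9-fold higher number from compound 2 to compound 1 (0.28 log units; within the scatter) lies within the scatter, so these two values cannot be told apart. Compound 3 rests on a different core; how its core differs from that of compound 2 is not broken down here. Among the three, compound 3 stands lowest, with compound 2 nearest to it.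

Compound 4 `O=C(O)/C=C/c1ccc(/C(=C(\c2ccc(F)cc2Cl)C2CCC2)c2ccc3nccn3c2)cc1` has not been measured. It arises from compound 3 by the same change at the same place: a group of 9 heavy atoms (7 carbon, 2 nitrogen; one five-membered aromatic ring with 2 hetero atoms, one six-membered aromatic ring with 1 hetero atom) in place of a group of 9 heavy atoms (7 carbon, 1 nitrogen, 1 sulfur; one five-membered aromatic ring with 2 hetero atoms, one six-membered aromatic ring of carbon only), on a double-bonded chain carbon bound to an aromatic carbon and a double-bonded chain carbon. Among the measured compounds shown here, the only guide is the earlier step, and since that one stayed within the scatter, a similarly small step is expected here, a 1.7-fold higher number from compound 3 to compound 4 (0.22 log units; within the scatter), resting on a 1.9-fold higher number from compound 2 to compound 1 (0.28 log units; within the scatter). Compound 4 is therefore estimated at 5 nM in this assay, most likely between 2 nM and 15 nM.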

Compound 4, half-maximal inhibitory concentration: 4.4 nM
The estimate for compound 4 lay 1.1-fold (0.06 log units) above the measured number; low and high end bracket the measured number.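

In this assay, putting the nitrogen-containing two-ring group in place of the 1,3-benzothiazol-5-yl group gives a 1.5-fold higher number from compound 3 to compound 4 (0.17 log units; within the scatter), so on the core of compound 3 this swap again produces no change that can be told from the scatter. The two cases agree when set side by side: the same change on two cores in this assay, a 1.9-fold higher number (0.28 log units; within the scatter) from compound 2 to compound 1 and a 1.5-fold higher number (0.17 log units; within the scatter) from compound 3 to compound 4, 1.3-fold (0.11 log units) apart, within the scatter of two such steps

This shows that, on these two cores, the swap could be carried from one to the other with the same result, a step too small to read. It does not show that the two groups are interchangeable on every core in the series, or in any test other than this one, and it gives no reason why the step stays so small.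

The compounds shown leave open what a group carrying an amine would do at this same place on the double-bonded chain carbon. They also leave open whether the swap would stay as small with an amide in place of the carboxylic acid.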